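The source may hold more compounds than are shown below. What is called first, only, known or untested is meant among the compounds shown, and "the series" means these compounds.

Compound 1 `COC(=O)/C=C/c1cccc(N(Cc2ccc(/C=C/c3ccccn3)cc2)C(=O)C2CCCCC2)c1`: 309 nM
Compound 2 `CCOc1cccc(-c2ccc(CN(C(=O)C3CCCCC3)c3cccc(/C=C/C(=O)OC)c3)cc2)c1`: 147 nM
Compound 3 `COC(=O)/C=C/c1cccc(N(Cc2ccc(C(C)(C)C)cc2)C(=O)C2CCCCC2)c1`: > 1000 nM

All three compounds were tested in an assay on isolated protein with Bile acid receptor (Homo sapiens) as the target; on this read-out lower numbers stand for an effect already at smaller amounts and higher numbers for an effect only at larger amounts of compound. Compound 3 stands at the weak end of this small set: in this assay its result is the limit of > 1000 nM in this assay, at which 1 of the 3 values shown sits, which is a limit of the assay and not a number. The two measured steps that lead to compound 3 both point the same way. The step of an at least 3.2-fold higher number from compound 1 to compound 3 (0.51 log units; beyond the scatter) and the step of an at least 6.8-fold higher number from compound 2 to compound 3 (0.83 log units; beyond the scatter) show that putting tert-butyl in place of a group carrying an aromatic ring raised the number well beyond the scatter.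

Compound 4 `COC(=O)/C=C/c1cccc(N(Cc2ccc(-c3ccc(OC(F)(F)F)cc3)cc2)C(=O)C2CCCCC2)c1` differs from compound 3 by 4-(trifluoromethoxy)phenyl in place of tert-butyl on an aromatic carbon. The group that enters is a phenyl ring bearing a substituent, and in that respect it resembles the 3-ethoxyphenyl of compound 2 more than the tert-butyl of compound 3. Going by the values given here, the expectation is therefore a step back downward, of a size like the one seen for compound 2 against compound 3, so that compound 4 is expected to show an at least 5.0-fold lower number from compound 3 to compound 4 (0.69 log units; beyond the scatter). On that basis compound 4 is estimated at 200 nM in this assay, with a range from 70 nM to 700 nM.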

Compound 4, half-maximal effective concentration: 264 nM
Beside the measured number, compound 4's estimate is 1.3-fold (0.12 log units) below it; low and high end bracket the measured number.
By their numbers in this assay, from the lowest: compounds 2, 4 and 1 (each within the scatter of the next, the first and the last beyond it). At a limit, above all of these: compound 3.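

Compound 3's result in this assay is a limit and not a number, so the step of an at least 3.7-fold lower number from compound 3 to compound 4 (0.57 log units; beyond the scatter) gives only the smallest possible size of the change. Going by these compounds alone, on this aromatic carbon, para to a large group, a phenyl ring bearing 4-(trifluoromethoxy) now joins 3-ethoxyphenyl and 2-(pyridin-2-yl)ethenyl as a third ring-bearing group on the low-number side of tert-butyl, the only group here without a ring, and none of the four compounds goes against this. Compound 4 cannot be separated from either neighbour, with a 1.8-fold higher number from compound 2 to compound 4 (0.25 log units; within the scatter) and a 1.2-fold lower number from compound 1 to compound 4 (0.07 log units; within the scatter), even though its two neighbours do differ from each other, with a 2.1-fold lower number from compound 1 to compound 2 (0.32 log units; beyond the scatter).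

The compounds shown leave open whether the aromatic ring itself matters or whether a ring-free group of similar length, such as an n-hexyl chain, would serve as well. They also leave open what a plain phenyl ring with no substituent, or one bearing an amine or a carboxylic acid, would give at this carbon in this assay.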